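Carbamate chain growth on a biaryl aniline core

The source may report more compounds than this note shows. Statements on the series, on what has been measured and on what is new or still open speak of the compounds shown alone.

Compound 1 `CN(C)c1ccc(-c2cccc(N)c2)cc1` carries a free amino group and gives 70% in an assay on COS-7 cells for inhibition of patatin-like phospholipase domain-containing protein 2 (Mus musculus), tested at 200 uM; on this read-out higher numbers stand for more inhibition at the one concentration tested (going by the name of the read-out) and lower numbers for less inhibition. Compound 2 `CCOC(=O)Nc1cccc(-c2ccc(N(C)C)cc2)c1` gives 93% in this assay, and compound 3 `CC(C)OC(=O)Nc1cccc(-c2ccc(N(C)C)cc2)c1` gives 69%. Compound 3 stands lowest of the three numbers, yet its gap to compound 1 is within the scatter, so only compound 2 sits clearly above it: a number 24 percentage points lower from compound 2 to compound 3 (beyond the scatter). The step of a number 23 percentage points higher from compound 1 to compound 2 (beyond the scatter) shows the ethoxycarbonyl group raising the number, whereas a number 1 percentage points lower from compound 1 to compound 3 (within the scatter) shows no change beyond the scatter.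

Compound 4 `CC(C)COC(=O)Nc1cccc(-c2ccc(N(C)C)cc2)c1` is compound 3 with a longer chain: isobutyl in place of isopropyl on an oxygen next to a carbonyl group. Among the measured compounds shown here, no measured pair repeats this exact change, so the only bearing step is the one from compound 2 to compound 3, where adding one carbon on the chain lowered the number. A further carbon is therefore expected to lower the number again, if at all, by a small amount: the step is estimated as a number 9 percentage points lower from compound 3 to compound 4 (within the scatter). In this assay compound 4 is expected to give about 60%, with a range from 35% to 85%.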

Compound 4, a percentage reported as inhibition, at one concentration (the size of the read-out at that concentration, not a potency): 90%
Beside the measured number, compound 4's estimate is 30 percentage points below it; the whole stated range lies below it.
By their numbers in this assay, from the lowest: compounds 3 and 1 (each within the scatter of the next); then compounds 4 and 2 (each within the scatter of the next).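

The number at this position does not fall steadily as the chain on the oxygen grows in this assay: with isobutyl in place of isopropyl there is a number 21 percentage points higher from compound 3 to compound 4 (beyond the scatter) and not a further loss, while a number 3 percentage points lower from compound 2 to compound 4 (within the scatter) leaves the isobutyl and ethyl carbamates level. The isobutoxycarbonyl group also stands clear of the free amino group, with a number 20 percentage points higher from compound 1 to compound 4 (beyond the scatter) as the step, so two of the three carbamates lie above compound 1, and compound 3 goes against that pattern. Nothing given here explains why the isopropyl carbamate departs from the other two.

The compounds shown leave open whether a straight propyl or butyl chain on the same oxygen would keep the number high. They also leave open how an amide in place of the carbamate would read, and what the potencies of compound 2 and compound 4 are, since this read-out reports a single concentration.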